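The source may report more compounds than this note shows. Statements on the series, on what has been measured and on what is new or still open speak of the compounds shown alone.

Working notes on the series.

Compound 1 `CC(=O)c1cc(-c2ccccc2)cc2cc(-c3ccccc3)[nH]c12` gives 51.4% in a functional assay on HeLa cells (Homo sapiens) for cytotoxicity, read by MTT assay, with a stated time of 2 days, tested at 100 uM; a higher number here means a weaker effect of the compound at the concentration tested, a lower number a stronger effect. Compound 2 `CC(=O)c1cc(-c2ccccc2)cc2cc(-c3ccc(F)cc3)[nH]c12` gives 68.3% in this assay, and compound 3 `COc1ccc(-c2cc3cc(-c4ccccc4)cc(C(C)=O)c3[nH]2)cc1` gives 32.8%. Of the three numbers, compound 2 stands highest: its nearest neighbour is compound 1, with a number 16.9 percentage points higher from compound 1 to compound 2 (beyond the scatter), and its furthest is compound 3, with a number 35.5 percentage points lower from compound 2 to compound 3 (beyond the scatter). The remaining step, a number 18.6 percentage points lower from compound 1 to compound 3 (beyond the scatter), points the same way as the step to compound 3.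

Compound 4 `CC(=O)c1cc(/C=C/c2ccccc2)cc2cc(-c3ccc(F)cc3)[nH]c12` is not yet measured. It differs from compound 2 in one place: 2-phenylethenyl in place of phenyl on an aromatic carbon. All three measured steps concern a substituent on the other pendant ring, that is the aryl ring bearing fluoro or methoxy; none touches the phenyl that is exchanged here. Going by the values given here, there is thus no measured step that bears on this change, and the measured steps give no direction for it. The expectation for compound 4 in this assay is therefore a step of a number 2.3 percentage points lower from compound 2 to compound 4 (within the scatter), which is to say no change beyond the scatter, with a wide range to reflect the lack of any bearing step. Compound 4 is estimated at 66% in this assay, between 42% and 90%.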

Compound 4, a percentage reported as activity, at one concentration (the size of the read-out at that concentration, not a potency): 24.3%
The estimate for compound 4 lay 41.7 percentage points above the measured number; the whole stated range lies above it.
By their numbers in this assay, from the lowest: compounds 4 and 3 (each within the scatter of the next); then compound 1; then compound 2.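

Going by these compounds alone, the carbon meta to the acetyl group, which carries phenyl in all the earlier compounds, proves highly responsive in this assay: the exchange of phenyl for 2-phenylethenyl gives a number 44 percentage points lower from compound 2 to compound 4 (beyond the scatter) on the fluoro-bearing background. Within the data shown here, the position therefore tolerates an extended group, and the change moves the read-out towards a stronger effect at the concentration tested, whereas the earlier steps showed only what substituents on the other pendant ring do. No measurement shown gives a reason for this step, and the entering group differs from phenyl both in its heavy-atom count and in the double bond outside the aromatic rings, so neither feature can be singled out.

From the compounds shown here alone, the step is seen on one background only, so it remains open whether the same exchange would act alike on compound 1, with its unsubstituted ring, or on compound 3, with its methoxy group. Also open, going by these compounds, is what a saturated 2-phenylethyl chain would do at this carbon, which would separate the double bond from the chain length, and what an amine or a carboxylic acid would do there.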